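Acid-bearing side chain replaces cyclopentyl on the indole nitrogen

The source may hold more compounds than are shown below. What is called first, only, known or untested is meant among the compounds shown, and "the series" means these compounds.

Measured so far:
compound 1 `CCn1cc(C(=O)C(=O)Nc2ccc(OC)nc2)c2ccccc21` — 219 nM
compound 2 `COc1ccc(NC(=O)C(=O)c2cn(C3CCCC3)c3ccccc23)cn1` — 370 nM

Both compounds were tested in a functional assay on FaDu cells (Homo sapiens) for cytotoxicity, read by MTT assay, with a stated time of 72 h; a higher number here means that more compound is tolerated, a lower number that less compound is tolerated. Compound 2 carries the highest of the two numbers, and its nearest neighbour is compound 1, but the step of a 1.7-fold higher number from compound 1 to compound 2 (0.23 log units; within the scatter) is within the scatter, so the two numbers cannot be told apart.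

Compound 3 `COc1ccc(NC(=O)C(=O)c2cn(C(C)(C)COCC(=O)O)c3ccccc23)cn1` has not yet been measured. It differs from compound 2 in one place: a group of 9 heavy atoms (6 carbon, 3 oxygen; no ring) in place of a group of 5 heavy atoms (5 carbon; one five-membered non-aromatic ring of carbon only), on an aromatic nitrogen.

For the measured compounds named here, only one measured step exists, and it exchanges ethyl for cyclopentyl on the same aromatic nitrogen; it stayed within the scatter. Going by the values given here, no measured step introduces a group of this kind, with oxygen atoms and a hydrogen-bond donor, at this position. The data therefore give no firm direction. Given that the only step at this position, a 1.7-fold higher number from compound 1 to compound 2 (0.23 log units; within the scatter), was small, compound 3 is estimated at 1500 nM, with a range from 300 nM to 8000 nM. This estimate means a step of a 4.1-fold higher number from compound 2 to compound 3 (0.61 log units; beyond the scatter), which the measurement will confirm or refute.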

Compound 3, concentration lethal to 50% of the cells: > 10000 nM
Compound 3 ended at the assay's limit (the forecaster's own chance of this, stated with the estimate: 25%); middle value at least 6.6-fold (0.82 log units) from the limit.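

At this position on the aromatic nitrogen, the earlier compounds had shown only two carbon-only groups, ethyl and cyclopentyl, whose numbers could not be told apart. The open chain of 9 heavy atoms shows that the position is not indifferent to every group, giving an at least 27-fold higher number from compound 2 to compound 3 (1.43 log units; beyond the scatter) and an at least 45-fold higher number from compound 1 to compound 3 (1.65 log units; beyond the scatter), both large steps. Having no ring cannot by itself account for this, since ethyl has no ring either and compound 1 stays within the scatter of compound 2; in this assay, compound 3 stands at a limit and not at a number: the limit of > 10000 nM in this assay, at which 1 of the 3 values shown sits.

The chain brings in its oxygen atoms, its double bond and its hydrogen-bond donor all at once, so the compounds shown do not tell which of these parts goes with the step, and how far compound 3 lies past its limit also stays open. A carbon-only chain of similar length, or a methyl ester or an amine in place of the carboxylic acid, would be needed to separate those parts.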